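Swapping a five-membered ring for a six-membered one

The source may hold more compounds than are shown below. What is called first, only, known or untested is meant among the compounds shown, and "the series" means these compounds.

Measured compounds:
Compound 1, `O=C(O)c1cn(-c2ccc(O)cc2)c2cc(-c3ccncc3)ccc2c1=O`: 20000 nM
Compound 2, `NC(=O)c1cn(-c2ccc(O)cc2Cl)c2cc(-n3cccn3)ccc2c1=O`: 600 nM

Within the data shown here, in an assay on isolated protein for inhibition of Calpain-1 catalytic subunit (Homo sapiens) (on this read-out lower numbers stand for stronger inhibition and higher numbers for weaker inhibition), compound 2 gives 600 nM, the lowest of the two numbers known, while compound 1 gives 20000 nM, a gap that lies beyond the scatter. Compound 1 and compound 2 differ at several places at once, so these two values alone do not tell how much any single change contributes.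

Compound 3, `NC(=O)c1cn(-c2ccc(O)cc2Cl)c2cc(-c3ccccn3)ccc2c1=O`, has not yet been measured. It keeps everything from compound 2 except one group: pyridin-2-yl in place of 1H-pyrazol-1-yl on an aromatic carbon. Among the measured compounds shown here, no pair of measured compounds shows this exact swap. For the measured compounds named here, there is no measured step to lean on. The change is small in size, and both groups are aromatic rings carrying a nitrogen, so the expectation is a step within or only modestly beyond the scatter, if anything toward a slightly weaker inhibition, a 1.7-fold higher number from compound 2 to compound 3 (0.22 log units; within the scatter). The estimated value for compound 3 in this assay is therefore 1000 nM, with a plausible range from 250 nM to 4000 nM.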

Compound 3, half-maximal inhibitory concentration: 30000 nM
Estimate against measurement, compound 3: 30-fold (1.48 log units) below; the measured number lies above the stated range.
By their numbers in this assay, from the lowest: compound 2; then compounds 1 and 3 (each within the scatter of the next).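

In this assay, putting pyridin-2-yl in place of 1H-pyrazol-1-yl on this aromatic carbon gives a 50-fold higher number from compound 2 to compound 3 (1.70 log units; beyond the scatter), so the position clearly distinguishes between these two groups. Both are aromatic rings that carry nitrogen, have no hydrogen-bond donors and have no net charge, yet they cannot be exchanged here without a large weakening of inhibition, which the earlier pair could not show because compound 1 and compound 2 differ at several places at once. The groups differ in ring size, in the number of hetero atoms and in the number of hydrogen-bond acceptors, but nothing available explains why the step is so large, or which of these differences matters.

The compounds shown leave open whether the five-membered ring itself or its nitrogen atoms carry the stronger inhibition, a question that groups such as phenyl or 1H-imidazol-1-yl at the same carbon would help to separate. From the compounds shown here alone, it also remains open whether a non-aromatic group there, such as a simple amine or a short alkyl chain, would fit the pattern of compound 2 or of compound 3.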